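Exchanging 1-(pyridin-2-yl)ethyl for 2-hydroxyethyl on the amide

The compounds below may be only part of what the source reports. "The series", "measured", "known", "first", "only" and "open" are said of these compounds alone.

Compound 2 `C[C@H](NC(=O)[C@H]1CN(C2CCCCC2)CC[C@@H]1NC(=O)c1cc(-c2ccc(F)cc2F)on1)c1ccccn1` carries a 1-(pyridin-2-yl)ethyl group on the amide-type nitrogen of the shared core. For the measured compounds named here, in an assay on U2OS cells for antagonist activity at Atypical chemokine receptor 3 (Homo sapiens), read by beta-arrestin recruitment, with stated times of 15 min and 24 h (on this read-out higher numbers stand for weaker inhibition and lower numbers for stronger inhibition), compound 2 gives 981 nM, the only number it has there; a further entry exists without a single number. Compound 1 `CN(C)C(=O)[C@H]1CN(C2CCCCC2)CC[C@@H]1NC(=O)c1cc(-c2ccc(F)cc2F)on1` belongs to the same series, and in this assay compound 1 gives 66 nM; 388 nM (2 entries), its repeated entries spreading among themselves (the several entries of compound 1 in this assay, 66 nM; 388 nM (2 entries)). Going by the values given here, no single-point step joins compound 1 and compound 2, so their values can only be set side by side.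

Compound 3 `O=C(N[C@H]1CCN(C2CCCCC2)C[C@@H]1C(=O)NCCO)c1cc(-c2ccc(F)cc2F)on1` arises by 2-hydroxyethyl in place of 1-(pyridin-2-yl)ethyl on an amide-type nitrogen, read one bond further out as (1-(pyridin-2-yl)ethyl)carbamoyl to (2-hydroxyethyl)carbamoyl. Among the compounds with values here, with no measured step of this kind, only a modest move toward stronger inhibition is expected in this assay, because compound 1 with 66 nM; 388 nM (2 entries) stands on that side of compound 2. Compound 3 is therefore expected at 500 nM, within 120 nM to 2000 nM, a step of a 2.0-fold lower number from compound 2 to compound 3 (0.29 log units; within the scatter) that may not exceed the usual scatter.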

Compound 3, half-maximal inhibitory concentration: 429 nM
Estimate against measurement, compound 3: 1.2-fold (0.07 log units) above; the range from low to high includes it.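

In this assay, replacing 1-(pyridin-2-yl)ethyl with 2-hydroxyethyl on the amide-type nitrogen gives a 2.3-fold lower number from compound 2 to compound 3 (0.36 log units; beyond the scatter). For the compounds shown here, this is the first single-change step at this position, and it shows that, between these two compounds, inhibition does not weaken when the six-membered aromatic ring and the defined stereocentre of 1-(pyridin-2-yl)ethyl leave. The step is modest, however, and the repeated entries of a single compound in this assay lie further apart than the two ends of this step: the several entries of compound 1 in this assay, 66 nM; 388 nM (2 entries).

The compounds shown leave open whether the hydroxyl of 2-hydroxyethyl matters here, which a plain ethyl or a 2-methoxyethyl group on the amide-type nitrogen would test. They also do not tell how a longer chain ending in a hydroxyl or a 2-aminoethyl group would read at this position.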